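From Methoxy to Fluoro on an Aromatic Carbon

The compounds below may be only part of what the source reports. "The series", "measured", "known", "first", "only" and "open" are said of these compounds alone.

Among the measured compounds shown here, only two compounds have numbers so far in a functional assay on HepG2 cells (Homo sapiens) for antiproliferative activity, read by sulforhodamine B assay, with a stated time of 48 h; on this read-out higher numbers stand for weaker inhibition and lower numbers for stronger inhibition. Compound 1 `COc1ccc(OC)c(/C=C/C(=O)/C=C(O)/C=C/c2cc(OC)ccc2OC)c1` gives 5560 nM. Compound 2 `COc1ccc(/C=C/C(=O)C(=Cc2ccc(O)c(OC)c2)C(=O)/C=C/c2ccc(OC)cc2OC)c(OC)c1` gives 510 nM, the lower of the two numbers, so it is the stronger inhibitor of this pair, and the gap between them lies beyond the usual scatter of repeated measurements.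

Compound 3 `COc1ccc(/C=C/C(=O)C(=Cc2ccc(O)c(F)c2)C(=O)/C=C/c2ccc(OC)cc2OC)c(OC)c1` differs from compound 2 in one place: fluoro in place of methoxy on an aromatic carbon. Seen one bond further out, the same change turns 4-hydroxy-3-methoxyphenyl into 3-fluoro-4-hydroxyphenyl. For the measured compounds named here, no measured pair shows this swap, so the only anchor is compound 2 at 510 nM. The estimated step of a 1.2-fold higher number from compound 2 to compound 3 (0.07 log units; within the scatter) is expected to stay within the scatter, with no firm direction. For compound 3 the expected value in this assay is 600 nM, with an estimated range of 250 nM to 1500 nM.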

Compound 3, half-maximal inhibitory concentration: 1760 nM
Compound 3: middle estimate off by 2.9-fold (0.47 log units), on the low side; the whole stated range lies below it.
By their numbers in this assay, from the lowest: compound 2; then compound 3; then compound 1.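

Swapping methoxy for fluoro on this aromatic carbon, ortho to a hydroxy group, gives a 3.5-fold higher number from compound 2 to compound 3 (0.54 log units; beyond the scatter) in this assay, so here the swap weakens inhibition by more than the usual scatter. Among the compounds shown here, compound 1 and compound 2 differ in more than one place, so only this pair shows that a change at this one position can shift the number on its own. Nothing measured here explains the loss.

Going by these compounds, whether chloro, ethoxy, or an amine at this position would match compound 2, or fall further away like fluoro, remains open. So does whether replacing the other methoxy groups of compound 2 with fluoro would have a similar effect, since a single step at one position gives no general rule.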